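A Chloro for a Methyl on an Aromatic Carbon

The compounds below may be only part of what the source reports. "The series", "measured", "known", "first", "only" and "open" are said of these compounds alone.

In a functional assay on CHP-134 cells (Homo sapiens) for antiproliferative activity, with a stated time of 72 h (a higher number here means a weaker inhibitor, a lower number a stronger inhibitor), compound 1 (`Cc1cc(C)cc(C(=O)N(CCC(=O)NCc2ccccc2)Cc2ccc(C(=O)NO)cc2)c1`) gives 2030 nM and compound 2 (`Cc1ccc(CNC(=O)CCN(Cc2ccc(C(=O)NO)cc2)C(=O)c2ccc(N(C)C)cc2)cc1`) gives 420 nM as the lower of the two numbers, a gap beyond the scatter. Compound 3 (`CN(C)c1ccc(C(=O)N(CCC(=O)NCc2ccc(Cl)cc2)Cc2ccc(C(=O)NO)cc2)cc1`) carries chloro in place of methyl on an aromatic carbon, para to a large group (chloro in place of methyl on an aromatic carbon). Within the data shown here, no measured pair shows this change. The step (a 1.1-fold lower number from compound 2 to compound 3 (0.02 log units; within the scatter)) in this assay is expected to stay within the scatter, with no direction foreseen. Compound 3 is estimated at 400 nM within a range from 180 nM to 900 nM for now.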

Compound 3, half-maximal inhibitory concentration: 610 nM
Beside the measured number, compound 3's estimate is 1.5-fold (0.18 log units) below it; the range from low to high includes it.
By their numbers in this assay, from the lowest: compounds 2 and 3 (each within the scatter of the next); then compound 1.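

In this assay, among these compounds, chloro in place of methyl on an aromatic carbon, para to a large group, gives a 1.5-fold higher number from compound 2 to compound 3 (0.16 log units; within the scatter) and so provides the first measured step at this position. In this one pair, 4-methylbenzyl and 4-chlorobenzyl cannot be told apart.

Going by these compounds, whether a methoxy group, an amine or a carboxylic acid at the same place would also leave the number within the scatter remains open. So does whether this change would read the same with the other amide group of compound 1. Nothing measured here offers an explanation for this result.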